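Difluorophenyl swap from compound 2 to compound 4

The source may hold more compounds than are shown below. What is called first, only, known or untested is meant among the compounds shown, and "the series" means these compounds.

compound 1 `O=C(Nc1ccc2sc(-c3ccc(F)c(F)c3)nc2c1)N1CCC(F)CC1` gives > 50000 nM as a limit
compound 2 `O=C(Nc1ccc2sc(-c3ccc(F)c(F)c3)nc2c1)N1CCCC1` gives > 50000 nM as a limit
compound 3 `O=C(Nc1ccc2sc(-c3ccc(F)c(F)c3)nc2c1)N1CCCCC1` gives > 50000 nM as a limit

In an ADME assay on HepG2 cells (Homo sapiens) for inhibition, read by resazurin assay, with a stated time of 48 h (on this read-out higher numbers stand for an effect only at larger amounts of compound and lower numbers for an effect already at smaller amounts), compound 2 gives > 50000 nM as a limit and not as a number. Among the measured compounds shown here, the series so far offers only the limit of > 50000 nM in this assay, at which 3 of the 3 values shown sit, and no measured number.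

Compound 4 `O=C(Nc1ccc2sc(-c3cccc(F)c3F)nc2c1)N1CCCC1` alters compound 2 in one place. The change is 2,3-difluorophenyl in place of 3,4-difluorophenyl on an aromatic carbon and it sits on an aromatic carbon of a five-membered aromatic ring with 1 nitrogen and 1 sulfur.

The three measured steps are (a step that the two limits leave unreadable from compound 1 to compound 2) and (a step that the two limits leave unreadable from compound 1 to compound 3) and (a step that the two limits leave unreadable from compound 2 to compound 3) and none has a readable size. All three alter the group on the carbonyl carbon, so none of them tests the difluorophenyl group.

With no readable step to go on, no step beyond the usual scatter is expected in this assay and no direction can be given. Another limit is the likeliest result. The expected step is a step that the limit leaves unreadable from compound 2 to compound 4 and it remains only an estimate. For compound 4 the estimated value is 60000 nM with an expected range from 25000 nM to 120000 nM on this reasoning.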

Compound 4, half-maximal effective concentration: > 50000 nM
Compound 4 ended at the assay's limit (the forecaster's own chance of this, stated with the estimate: 80%); the middle value is on the limit's open side.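

In this assay compound 4 gives > 50000 nM, a limit and not a number. With compound 2 also at a limit, no step can be read for the difluorophenyl swap between compound 2 and compound 4: the limit of > 50000 nM in this assay, at which 4 of the 4 values shown sit.

The compounds shown leave open whether any member of this series gives a measurable value in this assay.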